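From an alkyl sulfonate to an aryl sulfonate

This account rests on a few compounds, and the source may have more. Where it says the series, first, only, none or still open, it means among the compounds named here.

Compound 1 `COS(=O)(=O)c1ccc(F)c2ncc(I)cc12` was tested in an assay for inhibition of methylcytosine dioxygenase TET2 (Homo sapiens), read by mass spectrometry, with stated times of 30 min and 1 h; a lower number here means a stronger inhibitor, a higher number a weaker inhibitor; there compound 1 gives > 200000 nM, which is a limit of the assay and not a number. Compound 2 `CCCCCOS(=O)(=O)c1ccc(F)c2ncc(I)cc12`, butyl in place of hydrogen on a saturated chain carbon bound to an oxygen on an unsaturated carbon, likewise reaches only a limit: in this assay compound 2 gives > 200000 nM. The step that the two limits leave unreadable from compound 1 to compound 2 therefore cannot be read, and compound 2 stands at the limit of > 200000 nM in this assay, at which 2 of the 2 values shown sit. The change to compound 3 `Nc1cccc(OS(=O)(=O)c2ccc(F)c3ncc(I)cc23)c1` is 3-aminophenyl in place of pentyl on an oxygen. Among the measured compounds shown here, the only measured step has no readable size, so it offers no guide to the direction or size of the change in this assay, and the outcome remains open. Compound 3 is accordingly expected at 250000 nM, between 40000 nM and 1500000 nM. That estimate amounts to an expected step that the limit leaves unreadable from compound 2 to compound 3.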

Compound 3, half-maximal inhibitory concentration: > 200000 nM
Compound 3 ended at the assay's limit; the forecaster's own chance of this, stated with the estimate: 75%; the middle value is on the limit's open side.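

Among the compounds shown here, compound 3 also reaches only a limit in this assay, so no step among compound 1, compound 2 and compound 3 can be read: the limit of > 200000 nM in this assay, at which 3 of the 3 values shown sit. The compounds shown leave open whether any group on that oxygen would give a readable value in this assay.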